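A few compounds are considered here, and "the series" means these few. Any claim that something is new, unique, unknown or untested is made for them only; others in the source may bear on it.

Within the data shown here, in a functional assay on DLD-1 cells (Homo sapiens) for cytotoxicity, read by MTT assay (on this read-out lower numbers stand for stronger inhibition and higher numbers for weaker inhibition), compound 3 (`CCOc1cc(C=C(C(=O)/C=C/c2ccc(O)c(OCC)c2)C(=O)/C=C/c2ccc(O)c(OCC)c2)ccc1O`) reads 1360 nM and holds the lowest of the three numbers so far. It stands clear, by more than the scatter, of compound 1 (`COc1cc(/C=C/C(=O)C(=Cc2ccc(OC)c(OC)c2)C(=O)/C=C/c2ccc(O)c(OC)c2)ccc1O`) at 3070 nM and of compound 2 (`CCOc1cc(C=C(C(=O)/C=C/c2ccc(O)c(OC)c2)C(=O)/C=C/c2ccc(O)c(OC)c2)ccc1O`) at 4260 nM in this series.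

Compound 4 (`CCOc1cc(/C=C/C(=O)C(=Cc2ccc(OCC)c(OCC)c2)C(=O)/C=C/c2ccc(O)c(OCC)c2)ccc1O`) differs from compound 3 in one place. The change is ethyl in place of hydrogen on an oxygen on an aromatic ring and reads hydroxy to ethoxy, or 3-ethoxy-4-hydroxyphenyl to 3,4-diethoxyphenyl.

Among the measured compounds shown here, the one measured step that bears on this is a 1.4-fold higher number from compound 1 to compound 2 (0.14 log units; within the scatter) and it lies within the scatter. Read in reverse, that step also replaces a hydroxy group with an ether, but the groups around it are not the same as here. For the measured compounds named here, no measured pair tests hydroxy to ethoxy on compound 3 itself, so the evidence is thin.

In this assay no step beyond the scatter is therefore expected, only a slight lean towards a lower number. The estimated move is a 1.2-fold lower number from compound 3 to compound 4 (0.07 log units; within the scatter) and no larger. Compound 4 is estimated at 1150 nM with an expected range from 520 nM to 2500 nM on this read-out.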

Compound 4, half-maximal inhibitory concentration: 3450 nM
Compound 4: middle estimate off by 3.0-fold (0.48 log units), on the low side; measured number outside the range, above it.
By their numbers in this assay, from the lowest: compound 3; then compounds 1, 4 and 2 (each within the scatter of the next).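

In this assay, the ether on this oxygen gives a 2.5-fold higher number from compound 3 to compound 4 (0.40 log units; beyond the scatter), the only step among the compounds shown that is printed as beyond the scatter for a single change. The earlier step, a 1.4-fold higher number from compound 1 to compound 2 (0.14 log units; within the scatter), also separated a free hydroxy form from an ether form, but it stayed within the scatter and also involved a different set of groups around the change, so it could not show that this position responds to the change. With the ethoxy groups of compound 3 in place, the free hydroxy form carries the lower number, and ethyl in place of hydrogen on an oxygen on an aromatic ring is therefore not a neutral change in this setting, although no measurement shown gives a reason for the step.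

The compounds shown leave open whether the step belongs to ethyl in particular or to any group on this oxygen, a question that a methyl ether, a longer chain such as butyl, or a chain ending in a carboxylic acid would address. They also leave open whether the same change on the other hydroxy groups of compound 3 would give a step of similar size.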